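This account rests on a few compounds, and the source may have more. Where it says the series, first, only, none or still open, it means among the compounds named here.

Measured compounds:
compound 1 `Cn1nc(-c2ccccc2)c2c1OC(N)=C(C#N)C2c1ccc(F)cc1` — > 10000 nM
compound 2 `COc1ccc(C2C(C#N)=C(N)Oc3c2c(-c2ccccc2)nn3C)cc1F` — > 10000 nM
compound 3 `CC(C)c1ccc(C2C(C#N)=C(N)Oc3c2c(-c2ccccc2)nn3C)cc1` — 5400 nM

All values come from a functional assay on NCI-H2122 cells (Homo sapiens) for inhibition, read by microscopy, with a stated time of 10 days; on this read-out lower numbers stand for stronger inhibition and higher numbers for weaker inhibition. Compound 1 gives only a limit of the assay, > 10000 nM, and no number. Compound 2 likewise gives only a limit, > 10000 nM. Going by the values given here, compound 3 is the one compound of the three with a number in this assay, 5400 nM; it stands apart from the other two only because they sit at the limit of > 10000 nM in this assay, at which 2 of the 3 values shown sit. The steps toward it read as an at least 1.8-fold lower number from compound 1 to compound 3 (0.26 log units; that floor lies within the scatter) and an at least 1.8-fold lower number from compound 2 to compound 3 (0.26 log units; that floor lies within the scatter), so neither separates compound 3 from the limits beyond the scatter, and a step that the two limits leave unreadable from compound 1 to compound 2 cannot be read at all.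

Compound 4 `Cn1nc(-c2ccccc2)c2c1OC(N)=C(C#N)C2c1ccncc1` differs from compound 3 by pyridin-4-yl in place of 4-isopropylphenyl on a saturated ring carbon. Among the compounds with values here, no measured step exchanges an aryl group for a pyridine at this position, so none bears directly on it; the steps into compound 3 show only that the 4-isopropylphenyl group sits at the low end of what has been seen. With the isopropyl gone, compound 4 is expected to drift back toward the limit, a step estimated as a 1.9-fold higher number from compound 3 to compound 4 (0.27 log units; within the scatter) in this assay. For compound 4 the estimate in this assay is 10000 nM, with a range from 3000 nM to 30000 nM.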

Compound 4, half-maximal inhibitory concentration: 5200 nM
The estimate for compound 4 lay 1.9-fold (0.28 log units) above the measured number; the range from low to high includes it.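

In this assay the exchange on the saturated ring carbon reads as a 1.0-fold lower number from compound 3 to compound 4 (0.02 log units; within the scatter), so among the compounds shown the isopropyl group is not needed for a number to appear at this position, and a pyridin-4-yl group serves as well as 4-isopropylphenyl. Against the other two aryl groups the readings are an at least 1.9-fold lower number from compound 2 to compound 4 (0.28 log units; that floor lies within the scatter) and an at least 1.9-fold lower number from compound 1 to compound 4 (0.28 log units; that floor lies within the scatter), so pyridin-4-yl cannot be placed beyond the scatter from 3-fluoro-4-methoxyphenyl or from 4-fluorophenyl. Compound 1 and compound 2 each give a limit and not a number, so the comparison at this position rests on compound 3 and compound 4 alone: the limit of > 10000 nM in this assay, at which 2 of the 4 values shown sit.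

Open, on these data alone, is whether the ring nitrogen matters where it stands, which pyridin-3-yl on the same carbon would address, and whether a saturated amine such as piperidin-4-yl would keep a number in this assay. Also open, as far as these compounds go, is whether a carboxylic acid on the aromatic ring at this position would leave the read-out level with compound 3 and compound 4 or send it back to the limit.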